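This account rests on a few compounds, and the source may have more. Where it says the series, first, only, none or still open, it means among the compounds named here.

In a functional assay on NCI-H460 cells (Homo sapiens) for cytotoxicity, read by MTT assay, with a stated time of 72 h (on this read-out lower numbers stand for stronger inhibition and higher numbers for weaker inhibition), compound 1 `CCN(CC)Cc1ccc2nc(NC(=O)N/N=C/c3cn(Cc4ccc(Cl)cc4Cl)c4ccccc34)sc2c1` gives 1080 nM, while compound 2 `CCN(CC)Cc1ccc2nc(NC(=O)N/N=C/c3cn(Cc4ccc(Cl)cc4)c4ccccc34)sc2c1` gives 370 nM, the lower of the two numbers. Compound 3 `CCN(CC)Cc1ccc2nc(NC(=O)N/N=C/c3c[nH]c4ccccc34)sc2c1` differs from compound 2 by a larger change: hydrogen in place of 4-chlorobenzyl on an aromatic nitrogen. For the measured compounds named here, the only measured step, a 2.9-fold lower number from compound 1 to compound 2 (0.47 log units; beyond the scatter), takes one chloro off the benzyl group and is modest, though beyond the scatter. Going by the values given here, it is only a loose guide here, as no measured compound lacks the whole group. The expected change, toward weaker inhibition in this assay, is a 4.1-fold higher number from compound 2 to compound 3 (0.61 log units; beyond the scatter). Compound 3 is expected at 1500 nM, with an estimated range of 350 nM to 7000 nM.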

Compound 3, half-maximal inhibitory concentration: 3140 nM
The estimate for compound 3 lay 2.1-fold (0.32 log units) below the measured number; measured number inside the range.
By their numbers in this assay, from the lowest: compound 2; then compound 1; then compound 3.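

Replacing 4-chlorobenzyl with hydrogen on the aromatic nitrogen gives an 8.5-fold higher number from compound 2 to compound 3 (0.93 log units; beyond the scatter) in this assay, and replacing 2,4-dichlorobenzyl with hydrogen gives a 2.9-fold higher number from compound 1 to compound 3 (0.46 log units; beyond the scatter) on the same read-out. Both compounds with a benzyl group on this nitrogen therefore inhibit more strongly than the compound that carries only hydrogen there, whichever of these two benzyl groups is present. No measurement here explains this difference. Still open, as far as these compounds go, is whether the benzyl ring is needed, or whether a small group such as methyl on this nitrogen would serve as well. An unsubstituted benzyl group would also show how much the remaining chloro contributes.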